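From 3,4-dichlorophenyl to 3-bromophenyl at the assay limit

The compounds below may be only part of what the source reports. "The series", "measured", "known", "first", "only" and "open" are said of these compounds alone.

In a functional assay on SEM cells (Homo sapiens) for cytotoxicity, with a stated time of 72 h (on this read-out higher numbers stand for an effect only at larger amounts of compound and lower numbers for an effect already at smaller amounts), compound 1 `C=C[C@@](C)(/C=C/c1ccc(Nc2ccc(F)cc2)cc1)CCC=C(C)C` gives > 36600 nM, a limit and not a number. Compound 2 `C=C[C@@](C)(/C=C/c1ccc(-c2ccc(F)cc2)cc1)CCC=C(C)C` gives > 36600 nM, which is also a limit. Compound 3 `C=C[C@@](C)(/C=C/c1ccc(-c2ccc(Cl)c(Cl)c2)cc1)CCC=C(C)C` gives > 36600 nM, again only a limit. Compound 3 therefore has no numerical position among the three, because of the limit of > 36600 nM in this assay, at which 3 of the 3 values shown sit.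

Compound 4 `C=C[C@@](C)(/C=C/c1ccc(-c2cccc(Br)c2)cc1)CCC=C(C)C` carries 3-bromophenyl in place of 3,4-dichlorophenyl on an aromatic carbon, para to a large group: 3-bromophenyl in place of 3,4-dichlorophenyl on an aromatic carbon.

The measured step closest to this change is a step that the two limits leave unreadable from compound 2 to compound 3, which also exchanges one substituted phenyl for another. The other two are a step that the two limits leave unreadable from compound 1 to compound 2 and a step that the two limits leave unreadable from compound 1 to compound 3. None of the three has a readable size, so the data support no expected step beyond the scatter in this assay, and no direction. The expected step is a step that the limit leaves unreadable from compound 3 to compound 4. Compound 4 is expected to lie around the same limit, with an estimated value of 40000 nM and an expected range of 18000 nM to 80000 nM.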

Compound 4, half-maximal effective concentration: > 36600 nM
Compound 4: a limit, no number (the forecaster's own chance of this, stated with the estimate: 85%); the middle value is on the limit's open side.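

The steps joining compound 4 to compound 1, compound 2 and compound 3 cannot be read, because all four compounds share a single limit: the limit of > 36600 nM in this assay, at which 4 of the 4 values shown sit.

The compounds shown leave open whether any of these groups on the shared core gives a numerical value in this assay.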